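A few compounds are considered here, and "the series" means these few. Any claim that something is new, unique, unknown or untested is made for them only; others in the source may bear on it.

Two compounds share a core in which a substituted thiazole carries an ether to a bromonaphthalene and a chlorophenyl group. Compound 1 `CCOC(=O)CCCNc1ncc(C(Oc2ccc3cc(Br)ccc3c2)c2ccc(Cl)cc2)s1` bears an ester-tipped chain on the amine; in an ADME assay on HepG2 2.2.15 cells (Homo sapiens) for cytotoxicity (a higher number here means that more compound is tolerated, a lower number that less compound is tolerated), compound 1 is recorded as "not toxic" (no number reported). Compound 2 `O=C(Nc1ncc(C(Oc2ccc3cc(Br)ccc3c2)c2ccc(Cl)cc2)s1)c1ccc(Br)cc1` instead carries an amide built from a bromobenzoyl group. In this assay compound 2 gives > 50000 nM, which is a limit of the assay rather than a number. Compound 2 therefore stands at the limit of > 50000 nM in this assay, at which 1 of the 2 values shown sits, so only a floor is known for it.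

Compound 3 `O=C(Nc1ncc(C(Oc2ccc3cc(Br)ccc3c2)c2ccc(Cl)cc2)s1)c1ccc(Cl)nc1` differs from compound 2 by 6-chloropyridin-3-yl in place of 4-bromophenyl on a carbonyl carbon. Among the compounds with values here, no measured pair shows the effect of such a change here, so the expected step from compound 2 to compound 3 is a step that the limit leaves unreadable from compound 2 to compound 3, that is, no step beyond the usual scatter. Compound 3 is accordingly expected to read 60000 nM in this assay, within a range from 25000 nM to 150000 nM, and most likely to be reported only as a limit again.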

Compound 3, half-maximal cytotoxic concentration: "not toxic" (no number reported)
Compound 3: no number reported; no gap can be computed for the estimate.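

Compound 3 carries no number in this assay and compound 2 has only a limit, so no step can be read from compound 2 to compound 3. As far as these compounds go, what stays open is whether replacing 4-bromophenyl with 6-chloropyridin-3-yl changes the concentration tolerated.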